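The source may report more compounds than this note shows. Statements on the series, on what has been measured and on what is new or still open speak of the compounds shown alone.

Measured in an ADME assay on HepG2 cells (Homo sapiens) for cytotoxicity, with a stated time of 72 h; a higher number here means that more compound is needed for the effect, a lower number that less compound is needed:
- Compound 1 `Cc1cc(NC(=O)Nc2ccc(C)c(Cl)c2)c2ccccc2n1`: > 25000 nM
- Compound 2 `CSc1ccc(NC(=O)Nc2cc(C)nc3ccccc23)cc1`: 16000 nM
- Compound 3 `Cc1cc(NC(=O)Nc2ccccc2C(C)(C)C)c2ccccc2n1`: > 25000 nM

Compound 1 gives > 25000 nM, which is a limit of the assay and not a number. Compound 3 gives > 25000 nM, which is also a limit and not a number. Going by the values given here, this leaves compound 2, at 16000 nM, as the only compound with an actual number, so it is the one anchor for comparison.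

Compound 4 `Cc1cc(NC(=O)Nc2ccc(N(C)C)cc2)c2ccccc2n1` has not yet been measured. It differs from compound 2 in one place: dimethylamino in place of methylsulfanyl on an aromatic carbon. In words, dimethylamino takes the place of methylsulfanyl on an aromatic carbon, para to a large group.

Among the compounds with values here, no two measured compounds differ in just one place, so the data show no comparable step to judge this change by. The expected change is a 1.1-fold higher number from compound 2 to compound 4 (0.03 log units; within the scatter), and no shift beyond the usual scatter is expected in either direction. This expectation starts from compound 2 at 16000 nM. In this assay the estimate for compound 4 is 17000 nM, with an expected range of 8000 nM to 25000 nM.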

Compound 4, half-maximal effective concentration: > 25000 nM
Compound 4 gave a limit, no number; the forecaster's own chance of this, stated with the estimate: 35%; middle value at least 1.4-fold (0.16 log units) away from the limit.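

In this assay, going by these compounds alone, dimethylamino in place of methylsulfanyl on an aromatic carbon, para to a large group, gives the first step between two compounds that differ in one place: an at least 1.5-fold higher number from compound 2 to compound 4 (0.19 log units; that floor lies within the scatter). Compound 4 gives > 25000 nM, which is a limit and not a number, so this step has a floor but no known size. The step therefore cannot show how far this change moves the number, and the same ceiling holds most of the set:
the limit of > 25000 nM in this assay, at which 3 of the 4 values shown sit.

Within the data shown here, compound 2 remains the only compound with an actual number, so nothing yet shows whether methylsulfanyl is unusual at this position. A primary amine, a methoxy group or a longer chain in the same place could show whether any other group also gives a number below the limit.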